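The source may hold more compounds than are shown below. What is called first, only, known or untested is meant among the compounds shown, and "the series" means these compounds.

Measured compounds:
- compound 1 `CCOc1ccc(C(=O)CSc2nc3ccccc3[nH]2)cc1` — in a functional assay on HT-29 cells (Homo sapiens) for inhibition, read by WST assay, with a stated time of 48 h (a lower number here means a stronger inhibitor, a higher number a weaker inhibitor), compound 1 gives > 100000 nM
- compound 2 `O=C(CSc1nc2ccccc2[nH]1)c1ccc(F)cc1` — compound 2 gives 78700 nM
- compound 3 `COc1ccc(C(=O)CSc2nc3ccccc3[nH]2)cc1OC` — compound 3 gives 19100 nM

The value of compound 1 is a limit of the assay, not a number (the limit of > 100000 nM in this assay, at which 1 of the 3 values shown sits). Among the two numbers, compound 3 has the lowest; compound 2 gives 78700 nM, a higher number.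

Compound 4 `COc1ccc(C(=O)CSc2nc3ccccc3[nH]2)cc1O` differs from compound 3 by hydrogen in place of methyl on an oxygen on an aromatic ring. Among the compounds with values here, the only measured step, an at least 1.2-fold lower number from compound 1 to compound 2 (0.10 log units; that floor lies within the scatter), swaps fluoro for ethoxy on an aromatic carbon, starts from a limit and stays within the scatter; no measured step removes a methyl from an oxygen. So no step beyond the scatter is expected, in either direction, giving a 1.2-fold lower number from compound 3 to compound 4 (0.08 log units; within the scatter). Compound 4 is estimated at 16000 nM, between 5000 nM and 50000 nM.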

Compound 4, half-maximal inhibitory concentration: 33100 nM
For compound 4 the middle estimate is 2.1-fold (0.32 log units) below the measured one; the measured number falls inside the stated range.
By their numbers in this assay, from the lowest: compounds 3 and 4 (each within the scatter of the next); then compound 2. At a limit, above all of these: compound 1.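

In this assay, within the data shown here, hydroxy in place of methoxy on the aromatic ring gives a 1.7-fold higher number from compound 3 to compound 4 (0.24 log units; within the scatter), the first measured change at this oxygen. The methyl on this oxygen can therefore be removed without a change beyond the scatter, so this assay does not separate the two groups. Nothing available here bears on why they read alike.

As far as these compounds go, whether an amine or a carboxylic acid at this place would shift the number beyond the scatter remains open. So does whether the remaining methoxy tolerates the same change.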